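A pyridinyl in place of a dimethylamino on the hydrazone

The source may hold more compounds than are shown below. What is called first, only, known or untested is meant among the compounds shown, and "the series" means these compounds.

Compound 1 `CN(C)c1ccc(/C=N/Nc2nc3ccccc3s2)cc1` is one of two measured compounds. In a functional assay on HL-60 cells (Homo sapiens) for cytotoxicity, read by MTT assay, with a stated time of 72 h (on this read-out higher numbers stand for weaker inhibition and lower numbers for stronger inhibition), compound 1 gives > 16800 nM, which is a limit of the assay rather than a number. Compound 2 `O=C(O)c1ccccc1/C=N/Nc1nc2ccccc2s1` in this assay gives > 16800 nM, likewise a limit. Compound 1 thus stands at the limit of > 16800 nM in this assay, at which 2 of the 2 values shown sit. Compound 3 `C(=N/Nc1nc2ccccc2s1)\c1ccc(-c2ccccn2)cc1` has not yet been measured; it differs from compound 1 by pyridin-2-yl in place of dimethylamino on an aromatic carbon. Going by the values given here, no step between measured compounds is known, so the expected step that the limit leaves unreadable from compound 1 to compound 3 is none beyond the scatter. Compound 3 is therefore expected to give about 20000 nM in this assay, between 5000 nM and 60000 nM.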

Compound 3, half-maximal inhibitory concentration: 11500 nM
Compound 3: the middle estimate sits 1.7-fold (0.24 log units) above what was measured, within the range that was stated.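

With pyridin-2-yl in place of dimethylamino, para to a large group, compound 3 is the only compound shown whose result in this assay is a number rather than a limit. The change gives an at least 1.4-fold lower number from compound 1 to compound 3 (0.16 log units; that floor lies within the scatter), so this floor alone does not establish a real gain, and the full size of the step cannot be read. The remaining values stay limits: the limit of > 16800 nM in this assay, at which 2 of the 3 values shown sit.

From the compounds shown here alone, whether phenyl or a primary amine on the same aromatic carbon would also give a number in this assay remains open.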